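This account rests on a few compounds, and the source may have more. Where it says the series, first, only, none or still open, it means among the compounds named here.

Measured in a functional assay on U-937 cells (Homo sapiens) for cytotoxicity, read by MTT assay, with a stated time of 48 h; a higher number here means a weaker inhibitor, a lower number a stronger inhibitor
compound 1 (`Nc1ccccc1Nc1nc(-c2cccc(F)c2)nc2ccc(F)cc12`) 47300 nM
compound 2 (`Cc1cccc(Nc2nc(-c3cccc(F)c3)nc3ccc(F)cc23)c1`) > 50000 nM

Compound 2 stands at the limit of > 50000 nM in this assay, at which 1 of the 2 values shown sits, and this is a limit, not a number. Compound 3 (`Cc1ccccc1Nc1nc(-c2cccc(F)c2)nc2ccc(F)cc12`) carries 2-methylphenyl in place of 3-methylphenyl on a nitrogen on an aromatic ring. Among the measured compounds shown here, with an at least 1.0-fold higher number from compound 1 to compound 2 (0.02 log units; that floor lies within the scatter) as the one measured step bearing on this change, and with only its floor known, no step beyond the scatter is expected in this assay here. The step expected is a number no higher from compound 2 to compound 3 (the limit leaves the size open) on this estimate. Compound 3 is estimated at 50000 nM with an expected range of 25000 nM to 90000 nM for the coming measurement.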

Compound 3, half-maximal inhibitory concentration: > 50000 nM
Compound 3: no number, only a limit (the forecaster's own chance of this, stated with the estimate: 55%); the middle value sits exactly at the limit.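

In this assay, compound 3 also gives a limit and not a number: the limit of > 50000 nM in this assay, at which 2 of the 3 values shown sit.

Methyl in place of amino on an aromatic carbon gives an at least 1.0-fold higher number from compound 1 to compound 3 (0.02 log units; that floor lies within the scatter). The step between the two methylphenyl compounds cannot be read, so the limits do not separate 2-methylphenyl from 3-methylphenyl on this nitrogen.

From the compounds shown here alone, whether any other group on the phenyl ring, such as a hydroxyl, a carboxylic acid or a longer alkyl chain, would give a readable number in this assay remains open.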